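Chloro to Methoxy: From Compound 1 Toward Compound 4

The compounds below may be only part of what the source reports. "The series", "measured", "known", "first", "only" and "open" are said of these compounds alone.

Compound 1 `C=C1C(=O)OC[C@H]1CCOC(=O)Nc1ccc(Cl)cc1` gives the lowest of the three numbers in a functional assay on RAW264.7 cells (Mus musculus) for inhibition, with a stated time of 30 min (a lower number here means a stronger inhibitor, a higher number a weaker inhibitor), at 390 nM. Compound 2 `C=C1C(=O)OC[C@H]1CCOC(=O)Nc1cccc(Br)c1` gives 590 nM, and compound 3 `C=C1C(=O)OC[C@@H]1CCOC(=O)Nc1cccc(Br)c1` gives 840 nM; the step of a 1.4-fold higher number from compound 2 to compound 3 (0.15 log units; within the scatter) stays within the scatter and rests only on (the fact that compounds 2 and 3 differ only in the configuration as drawn). Compound 4 `C=C1C(=O)OC[C@H]1CCOC(=O)Nc1ccc(OC)cc1` differs from compound 1 by methoxy in place of chloro on an aromatic carbon. No measured pair speaks to this exchange: the only measured step concerns configuration, not the group on the ring, so nothing among the shown compounds anchors the direction. The step of a 1.5-fold higher number from compound 1 to compound 4 (0.19 log units; within the scatter) is therefore expected to be modest, with a wide range on either side. The estimate for compound 4 is 600 nM, expected to fall between 250 nM and 1500 nM.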

Compound 4, half-maximal inhibitory concentration: 710 nM
Estimate against measurement, compound 4: 1.2-fold (0.07 log units) below; the measured number falls inside the stated range.
By their numbers in this assay, from the lowest: compounds 1, 2, 4 and 3 (each within the scatter of the next, the first and the last beyond it).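

In this assay, the place para to a large group on the aromatic ring now has its first direct exchange: a 1.8-fold higher number from compound 1 to compound 4 (0.26 log units; within the scatter) with methoxy in place of chloro. The entering methoxy brings a hydrogen-bond acceptor that chloro lacks, yet the step stays within the scatter. Nothing shown gives a reason for this step. On these data alone, whether an amine, a carboxylic acid or a longer chain at this place would also stay within the scatter remains open. So does whether methoxy would give a similar step in the opposite configuration of the core.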